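The compounds below may be only part of what the source reports. "The series", "measured", "known", "first", "only" and "open" are said of these compounds alone.

Compound 1, with the structure `COc1cc2c(Oc3ccc(NC(=O)c4nn(-c5ccccc5C(F)(F)F)c(=O)cc4C)cc3F)ccnc2cc1OCCCN1CCC(C)CC1`, is the reference point of this small set. In a functional assay on A549 cells (Homo sapiens) for inhibition, read by MTT assay, with a stated time of 72 h (on this read-out lower numbers stand for stronger inhibition and higher numbers for weaker inhibition), compound 1 gives 160 nM. Compound 2, `COc1cc2c(Oc3ccc(NC(=O)c4nn(-c5ccccc5C(F)(F)F)c(=O)cc4C)cc3F)ccnc2cc1OCCCN1CCN(C)CC1`, carries the change 4-methylpiperazin-1-yl in place of 4-methylpiperidin-1-yl on a saturated chain carbon, three bonds along the chain from an oxygen on an aromatic ring and gives 170 nM in this assay; the step of a 1.1-fold higher number from compound 1 to compound 2 (0.03 log units; within the scatter) is therefore flat. Compound 3, `COc1cc2c(Oc3ccc(NC(=O)c4nn(-c5cccc(F)c5)c(=O)cc4C)cc3F)ccnc2cc1OCCCN1CCC(C)CC1`, differs from compound 1 in its core by 3-fluorophenyl in place of 2-(trifluoromethyl)phenyl on an aromatic nitrogen; in this assay compound 3 gives 250 nM, and the step of a 1.6-fold higher number from compound 1 to compound 3 (0.19 log units; within the scatter) stays within the usual scatter as well.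

Compound 4, `COc1cc2c(Oc3ccc(NC(=O)c4nn(-c5cccc(F)c5)c(=O)cc4C)cc3F)ccnc2cc1OCCCN1CCN(C)CC1`, has not yet been measured. Within the data shown here, it differs from compound 3 by 4-methylpiperazin-1-yl in place of 4-methylpiperidin-1-yl on a saturated chain carbon, three bonds along the chain from an oxygen on an aromatic ring, the same change as the one from compound 1 to compound 2, made at the same place and on the core of compound 3. Since that change earlier gave a 1.1-fold higher number from compound 1 to compound 2 (0.03 log units; within the scatter), the step from compound 3 to compound 4 is expected to be similarly small, about a 1.1-fold higher number from compound 3 to compound 4 (0.03 log units; within the scatter), and compound 4 is thus estimated to give 270 nM in this assay, with a plausible range from 150 nM to 480 nM.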

Compound 4, half-maximal inhibitory concentration: 150 nM
Compound 4: the middle estimate sits 1.8-fold (0.26 log units) above what was measured, within the range that was stated.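

Replacing 4-methylpiperidin-1-yl with 4-methylpiperazin-1-yl on the core of compound 3 gives a 1.7-fold lower number from compound 3 to compound 4 (0.22 log units; within the scatter) in this assay, and this step does not differ from the one seen for the same change on the core of compound 1: the same change on two cores in this assay, a 1.1-fold higher number (0.03 log units; within the scatter) from compound 1 to compound 2 and a 1.7-fold lower number (0.22 log units; within the scatter) from compound 3 to compound 4, 1.8-fold (0.25 log units) apart, within the scatter of two such steps

The change to 3-fluorophenyl from 2-(trifluoromethyl)phenyl, read with the 4-methylpiperazin-1-yl group in place, gives a 1.1-fold lower number from compound 2 to compound 4 (0.05 log units; within the scatter), and it likewise agrees with its earlier counterpart: the same change on two cores in this assay, a 1.6-fold higher number (0.19 log units; within the scatter) from compound 1 to compound 3 and a 1.1-fold lower number (0.05 log units; within the scatter) from compound 2 to compound 4, 1.8-fold (0.25 log units) apart, within the scatter of two such steps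

Across these compounds, both changes therefore stay flat on both cores, but since each step lies within the scatter, this does not show that a step of real size would carry from one core to another, nor does it say anything about cores beyond these.

The compounds shown leave open whether the picture would hold with a morpholine or a dimethylamino group at the end of the chain, or with a shorter or longer chain. They also leave open what an unsubstituted phenyl or a methoxyphenyl on the aromatic nitrogen would give.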